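This account rests on a few compounds, and the source may have more. Where it says the series, first, only, none or still open, it means among the compounds named here.

Three compounds share one core and differ only at the carbonyl end of a side chain. Compound 1 `O=C(O)CCc1cccc2c1B(O)OC2` carries a hydroxy group on the carbonyl carbon. Compound 2 `O=C(CCc1cccc2c1B(O)OC2)Nc1ccccc1` has an anilino group there instead, and compound 3 `O=C(CCc1cccc2c1B(O)OC2)NCc1ccccc1` has a benzyl group on the amide-type nitrogen. All three were tested in an ADME assay on WI-38 cells (Homo sapiens) for cytotoxicity, read by MTT assay, with a stated time of 72 h; on this read-out higher numbers stand for weaker inhibition and lower numbers for stronger inhibition. For compound 1 the result in this assay is a limit of the assay, > 100000 nM. Compound 2 gives 30000 nM in this assay. For compound 3 the result in this assay is again a limit, > 100000 nM. Compound 3 therefore sits at the limit of > 100000 nM in this assay, at which 2 of the 3 values shown sit, not at a measured number. The measured steps are an at least 3.3-fold lower number from compound 1 to compound 2 (0.52 log units; beyond the scatter) and an at least 3.3-fold higher number from compound 2 to compound 3 (0.52 log units; beyond the scatter).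

Compound 4 `O=C(CCc1cccc2c1B(O)OC2)Nc1nccs1` has not yet been measured. It differs from compound 3 in one place: 1,3-thiazol-2-yl in place of benzyl on an amide-type nitrogen. The step that bears on it is an at least 3.3-fold higher number from compound 2 to compound 3 (0.52 log units; beyond the scatter), which also exchanged the group on the amide-type nitrogen and was at least modest. Because that step an at least 3.3-fold higher number from compound 2 to compound 3 (0.52 log units; beyond the scatter) ran from an aromatic ring on the nitrogen to a benzyl group, and compound 4 again puts an aromatic ring directly on the nitrogen, a modest move toward stronger inhibition is expected, though a further limit is also possible. Compound 4 is expected to give about 60000 nM in this assay, between 20000 nM and 200000 nM. That estimate means an expected step of an at least 1.6-fold lower number from compound 3 to compound 4 (0.22 log units; that floor lies within the scatter).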

Compound 4, half-maximal inhibitory concentration: > 100000 nM
Compound 4: only a limit was reported (the forecaster's own chance of this, stated with the estimate: 50%); at least 1.6-fold (0.22 log units) between middle value and limit.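

Putting 1,3-thiazol-2-yl in place of phenyl on the amide-type nitrogen gives an at least 3.3-fold higher number from compound 2 to compound 4 (0.52 log units; beyond the scatter), so in this assay an aromatic ring set directly on that nitrogen does not by itself bring a measured number. Until now, compound 2 could be read as showing that any such ring would do, but among the groups shown here only phenyl on this nitrogen gives a value that is not a limit, and the rest of the series sits at one value: the limit of > 100000 nM in this assay, at which 3 of the 4 values shown sit. The steps joining compound 4 to compound 3 and to compound 1 cannot be read, as each has a limit at both ends.

On these data alone, it stays open how much of the result of compound 2 belongs to the plain phenyl ring, which a pyridin-2-yl group or a 4-chlorophenyl group on the same nitrogen would help to show. The limits also leave open how far compound 1, compound 3 and compound 4 differ from one another, and a test at higher concentrations would be needed to tell them apart.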